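The source may report more compounds than this note shows. Statements on the series, on what has been measured and on what is new or still open speak of the compounds shown alone.

compound 1 `CC1=C2[C@H](/C=C(\C)C(=O)NCc3cccc(F)c3)CC[C@@H](C)[C@H]2CC1`: 9600 nM
compound 2 `CC1=C2[C@H](/C=C(\C)C(=O)NCc3ccc(F)cc3)CC[C@@H](C)[C@H]2CC1`: 9600 nM
compound 3 `CC1=C2[C@H](/C=C(\C)C(=O)NCCC(C)C)CC[C@@H](C)[C@H]2CC1`: "not active" (no number reported)

In an ADME assay on cells (Keratinocyte, Homo sapiens) for inhibition, read by fluorescence, with stated times of 2 h and 72 h (on this read-out lower numbers stand for stronger inhibition and higher numbers for weaker inhibition), compound 3 has no single number, being reported only as "not active" (no number reported). Compound 4 `COCCNC(=O)/C(C)=C/[C@@H]1CC[C@@H](C)[C@H]2CCC(C)=C12` differs from it at one place: methoxy in place of isopropyl on a saturated chain carbon, two bonds along the chain from an amide-type nitrogen. In words, methoxy stands in place of isopropyl on a saturated chain carbon, two bonds along the chain from an amide-type nitrogen. Within the data shown here, the only measured step, no change at the digits printed from compound 1 to compound 2 (within the scatter), involves a different group and lies within the scatter, so it does not bear on this change. With no number for compound 3, no step size or direction can be stated. The nearest number is that of compound 1 at 9600 nM, and a reported number may well not appear. For compound 4 the estimated value is 15000 nM, with an expected range of 6000 nM to 40000 nM.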

Compound 4, half-maximal inhibitory concentration: "not active" (no number reported)
Nothing numeric was reported for compound 4, so the estimate cannot be set against anything.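

In this assay compound 3 and compound 4 are both reported only as "not active", so no step can be read between them. Nothing available offers an explanation for this result. The compounds shown leave open whether methoxy in place of isopropyl shifts inhibition at all.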